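Replacing piperidine with ethylpiperazine on the propoxy chain

The source may report more compounds than this note shows. Statements on the series, on what has been measured and on what is new or still open speak of the compounds shown alone.

Compound 1 `COc1cc2c(Nc3ccc(C#N)cc3)ncnc2cc1OCCCN1CCCCC1` is the reference point. In a functional assay on MCF7 cells (Homo sapiens) for antiproliferative activity, read by MTT assay, with a stated time of 72 h (on this read-out higher numbers stand for weaker inhibition and lower numbers for stronger inhibition), compound 1 gives 35100 nM. Compound 3 `COc1cc2c(Nc3ccc(C#N)cc3)ncnc2cc1OCCCN1CCC(CO)CC1` gives 35100 nM in this assay, and the step of no change at the digits printed from compound 1 to compound 3 (within the scatter) shows that hydroxymethyl on the saturated ring carbon leaves the read-out where it was. Compound 2 `COc1cc2c(Nc3ccc(C#N)cc3)ncnc2cc1OCCCN1CCC(O)CC1` reaches only a limit of the assay in this assay, namely > 100000 nM. On these data alone, the step of an at least 2.8-fold higher number from compound 1 to compound 2 (0.45 log units; beyond the scatter) rests on that limit, (the limit of > 100000 nM in this assay, at which 1 of the 3 values shown sits), so its true size is unknown beyond the floor it sets. Within the data shown here, compound 1 thus stands level with compound 3, and the only other value shown is a limit.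

Compound 4 `CCN1CCN(CCCOc2cc3ncnc(Nc4ccc(C#N)cc4)c3cc2OC)CC1` differs from compound 1 at the end of the three-carbon chain: 4-ethylpiperazin-1-yl in place of piperidin-1-yl on a saturated chain carbon, three bonds along the chain from an oxygen on an aromatic ring. Neither measured step bears directly on this exchange, since both alter a saturated ring carbon of the piperidin-1-yl group rather than replace the ring; they show one change within the scatter and one of at least modest size towards the limit. The author therefore expects, in this assay, a step of a 1.2-fold lower number from compound 1 to compound 4 (0.07 log units; within the scatter), that is none beyond the scatter, while allowing for the limit seen with compound 2. Compound 4 is estimated at 30000 nM, within 10000 nM to 100000 nM.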

Compound 4, half-maximal inhibitory concentration: 29900 nM
Compound 4: the middle estimate sits 1.0-fold (0.00 log units) above what was measured; low and high end bracket the measured number.
By their numbers in this assay, from the lowest: compounds 4, 1 and 3 (each within the scatter of the next). At a limit, above all of these: compound 2.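

In this assay, among these compounds, the earlier compounds altered only a saturated ring carbon of the piperidin-1-yl group, whereas compound 4 replaces the whole ring at this place on the saturated chain carbon, and 4-ethylpiperazin-1-yl in place of piperidin-1-yl gives a 1.2-fold lower number from compound 1 to compound 4 (0.07 log units; within the scatter), while the exchange for 4-(hydroxymethyl)piperidin-1-yl gives a 1.2-fold lower number from compound 3 to compound 4 (0.07 log units; within the scatter). The read-out at this end of the three-carbon chain therefore holds when the ring gains a second nitrogen and an ethyl group, so the place accepts an exchange of the ring itself and not only the hydroxymethyl group seen in compound 3. Compound 4 is separated from compound 2, which carries 4-hydroxypiperidin-1-yl, by an at least 3.3-fold lower number from compound 2 to compound 4 (0.52 log units; beyond the scatter), but the true size of that step is unknown, as it rests on a limit of the assay: the limit of > 100000 nM in this assay, at which 1 of the 4 values shown sits.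

What the compounds shown leave open is whether the ethyl group matters at all, as the unsubstituted piperazin-1-yl and the 4-methylpiperazin-1-yl group are not among them. Also open, on these data alone, is how morpholin-4-yl, a dimethylamino group or a carboxylic acid would read at this place, and what a longer chain would do.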